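Ring Closure at the Amine: Expecting Compound 3

A few compounds are considered here, and "the series" means these few. Any claim that something is new, unique, unknown or untested is made for them only; others in the source may bear on it.

Going by the values given here, compound 2 `CCN(CC)Cc1c(OC)cc(OC)c(C(=O)/C=C/c2ccccc2Cl)c1O` gives, in a functional assay on MCF7 cells (Homo sapiens) for antiproliferative activity, with a stated time of 72 h (a higher number here means a weaker inhibitor, a lower number a stronger inhibitor), a reading of 2700 nM, the lowest of the two numbers measured so far. Its nearest neighbour is compound 1 `CCN(C)Cc1c(OC)cc(OC)c(C(=O)/C=C/c2ccccc2Cl)c1O`, which in this assay gives 6800 nM. Among the compounds with values here, the single measured step, a 2.5-fold lower number from compound 1 to compound 2 (0.40 log units; beyond the scatter), comes from methyl in place of hydrogen on a saturated chain carbon bound to an amine nitrogen. Compound 3 `COc1cc(OC)c(C(=O)/C=C/c2ccccc2Cl)c(O)c1CN1CCCCC1` has not been measured; it differs from compound 2 by piperidin-1-yl in place of diethylamino on a saturated chain carbon bound to an aromatic carbon. Within the data shown here, the only step that bears on this change, a 2.5-fold lower number from compound 1 to compound 2 (0.40 log units; beyond the scatter), shows that methyl in place of hydrogen at the amine lowered the number modestly. Piperidin-1-yl in place of diethylamino is a related but different change, so a small drop or no step beyond the scatter is expected, a 1.4-fold lower number from compound 2 to compound 3 (0.15 log units; within the scatter). Compound 3 is therefore estimated at 1900 nM, within 700 nM to 5000 nM.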

Compound 3, half-maximal inhibitory concentration: 2600 nM
Estimate against measurement, compound 3: 1.4-fold (0.14 log units) below, and the stated range covers the measured number.
By their numbers in this assay, from the lowest: compounds 3 and 2 (each within the scatter of the next); then compound 1.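

Closing the two ethyl chains of diethylamino into the ring of piperidin-1-yl, on a saturated chain carbon bound to an aromatic carbon, leaves the reading in this assay unchanged within the scatter (a 1.0-fold lower number from compound 2 to compound 3 (0.02 log units; within the scatter)). Replacing ethyl(methyl)amino with the same ring gives a modest step beyond the scatter (a 2.6-fold lower number from compound 1 to compound 3 (0.42 log units; beyond the scatter)), so among these three compounds the lower number does not require an open-chain amine. No measurement at hand explains why the ring and the open chain read alike.

On these data alone, it remains open whether other rings at this place, such as pyrrolidin-1-yl or morpholin-4-yl, would give a similar reading. As far as these compounds go, the effect of a longer chain between the amine nitrogen and the shared core also remains open.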